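Moving the Carboxy Group Around an Aromatic Ring

The source may hold more compounds than are shown below. What is called first, only, known or untested is meant among the compounds shown, and "the series" means these compounds.

Compound 1 `Cc1c(OCCCCOc2ccc(F)c(C(=O)O)c2)ccc(C(=O)CC2CCCC2)c1O` and compound 2 `Cc1c(OCCCCOc2ccc(F)c(C(=O)O)c2)ccc(C(=O)CC(C)(C)C)c1O` share a core and differ only on a saturated chain carbon bound to a carbonyl carbon. In an assay on HEK293 cells for positive allosteric modulation of metabotropic glutamate receptor 2 (Rattus norvegicus), read by thallium flux, with a stated time of 2.5 min (on this read-out lower numbers stand for smaller maximal responses and higher numbers for larger maximal responses), compound 1 gives 81%, and compound 2 gives 94.6%. Compound 1 thus stands lowest of the two numbers, and the step of a number 13.6 percentage points higher from compound 1 to compound 2 (beyond the scatter) came with tert-butyl in place of cyclopentyl. Compound 3 `Cc1c(OCCCCOc2ccc(C(=O)O)cc2F)ccc(C(=O)CC2CCCC2)c1O` is built from the same atoms as compound 1 but joined differently: 4-carboxy-2-fluorophenyl in place of 3-carboxy-4-fluorophenyl on an oxygen on a saturated carbon. Within the data shown here, no measured step touches this part of the molecule; the one measured step altered the saturated chain carbon bound to a carbonyl carbon instead. Among the measured compounds shown here, with no comparable precedent, the expectation for the change from compound 1 to compound 3 is a step of no change at the digits printed from compound 1 to compound 3 (within the scatter), which does not go beyond the scatter. Compound 3 is therefore estimated at 81%, within a range from 65% to 97%.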

Compound 3, largest response reached (reported as percent of maximum), in percent of the reference or control that the assay uses: 83.8%
Beside the measured number, compound 3's estimate is 2.8 percentage points below it, within the range that was stated.
By their numbers in this assay, from the lowest: compounds 1 and 3 (each within the scatter of the next); then compound 2.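

In this assay, 4-carboxy-2-fluorophenyl in place of 3-carboxy-4-fluorophenyl on an oxygen on a saturated carbon gives a number 2.8 percentage points higher from compound 1 to compound 3 (within the scatter), so this read-out does not separate these two arrangements of the same atoms. Among these compounds, the earlier step concerned only the saturated chain carbon bound to a carbonyl carbon, so this is the first reading on the group attached through the oxygen, and moving its carboxy and fluoro substituents around the ring leaves the maximal response within the scatter. Nothing available explains this result.

As far as these compounds go, it remains open whether the two arrangements would also match with the tert-butyl of compound 2 in place of cyclopentyl. Also open, from the compounds shown here alone, is what an amide in place of the carboxylic acid, or chlorine in place of fluorine, would do on this ring.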